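Sulfamoyl in place of carboxy: compound 1 to compound 4

The source may report more compounds than this note shows. Statements on the series, on what has been measured and on what is new or still open speak of the compounds shown alone.

Values in a functional assay on PC-3 cells (Homo sapiens) for antiproliferative activity, read by sulforhodamine B assay (a higher number here means a weaker inhibitor of growth, a lower number a stronger inhibitor of growth), are as follows.
compound 1 `CC(C)(C)CCOc1cccc(O)c1C(=O)/C=C/c1ccc(C(=O)O)cc1` gives 6500 nM
compound 2 `CCCCOc1cccc(O)c1C(=O)/C=C/c1ccc(O)cc1` gives > 30000 nM (a limit)
compound 3 `O=C(/C=C/c1ccc(O)cc1)c1c(O)cccc1OCc1ccccc1` gives > 30000 nM (a limit)

Within the data shown here, compound 1 at 6500 nM holds the only number in this set. The other entries stand at the limit of > 30000 nM in this assay, at which 2 of the 3 values shown sit, and these are limits, not numbers. Compound 4 `CC(C)(C)CCOc1cccc(O)c1C(=O)/C=C/c1ccc(S(N)(=O)=O)cc1` differs from compound 1 by sulfamoyl in place of carboxy on an aromatic carbon, para to a large group (sulfamoyl in place of carboxy on an aromatic carbon). Among the measured compounds shown here, the one measured step is a step that the two limits leave unreadable from compound 2 to compound 3 and it lies at a different place from this change. It therefore gives neither a size nor a direction for the swap at hand. The step is expected to stay inside the usual scatter in this assay. This expectation rests on compound 1 at 6500 nM alone. The expected change is a 1.1-fold lower number from compound 1 to compound 4 (0.03 log units; within the scatter) and it carries no firm direction. The estimated value for compound 4 is 6000 nM with an expected range from 2000 nM to 20000 nM in this assay.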

Compound 4, concentration for 50% growth inhibition: 3250 nM
Compound 4: middle estimate off by 1.8-fold (0.27 log units), on the high side; the range from low to high includes it.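

In this assay, among these compounds, sulfamoyl in place of carboxy on an aromatic carbon, para to a large group, gives a 2.0-fold lower number from compound 1 to compound 4 (0.30 log units; within the scatter), the first step in this set that can be read. At this position the two groups cannot be told apart, so the swap shows that carboxy is not required for a measured number to be retained on the core of compound 1. The step between compound 2 and compound 3 cannot be read, as both stand at a limit and not at a number: the limit of > 30000 nM in this assay, at which 2 of the 4 values shown sit.

Going by these compounds, whether an amine or a nitrile on this aromatic carbon would give a step beyond the scatter stays open. Compound 2 and compound 3 carry hydroxy on this carbon but also differ from compound 1 in their chain, which leaves the effect of hydroxy here open as well.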